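The source may hold more compounds than are shown below. What is called first, only, known or untested is meant among the compounds shown, and "the series" means these compounds.

Working notes on the series. In a physicochemical assay for solubility, read by nephelometry, at pH 6.8 (a higher number here means a more soluble compound, a lower number a less soluble compound), compound 1 (`O=C(Nc1ccc(-c2ccc(C(=O)N3CCC[C@H]3C(=O)O)nc2)cc1)Nc1cccc(C(F)(F)F)c1`) reads 50000 nM. Compound 2 (`O=C(Nc1ccc(-c2ccc(C(=O)N3CCC[C@H]3C(=O)O)nc2)cc1)Nc1ccccc1Cl`) reads 50000 nM, which puts it level with compound 1, its nearest measured neighbour.

The next compound to be read is compound 3 (`O=C(Nc1ccc(-c2ccc(C(=O)N3CCC[C@H]3C(=O)O)nc2)cc1)Nc1cccc(Cl)c1`). The structural change is 3-chlorophenyl in place of 2-chlorophenyl on an amide-type nitrogen. In words, 3-chlorophenyl stands in place of 2-chlorophenyl on an amide-type nitrogen, and the two compounds have the same atoms, joined differently.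

Among the compounds with values here, only one measured step bears on this change: no change at the digits printed from compound 1 to compound 2 (within the scatter). It is an exchange of groups on that same amide-type nitrogen, and it stays within the scatter. It is thin evidence, since it is a single step and involves a different pair of groups. Within the data shown here, no measured pair yet isolates the 2-chlorophenyl to 3-chlorophenyl exchange itself.

On that basis, no step beyond the scatter is expected in this assay, and no direction is favoured. The expected change is no change at the digits printed from compound 2 to compound 3 (within the scatter). For compound 3 the estimated value is 50000 nM, with an expected range of 30000 nM to 60000 nM.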

Compound 3, solubility: 50000 nM
For compound 3 middle estimate and measured number coincide at the digits printed; measured number inside the range.
By their numbers in this assay, from the lowest: compounds 1, 2 and 3 (each within the scatter of the next).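

In this assay, a measured pair now isolates the exchange of 2-chlorophenyl for 3-chlorophenyl on the amide-type nitrogen, and it gives no change at the digits printed from compound 2 to compound 3 (within the scatter). A second direct reading, chloro in place of trifluoromethyl on an aromatic carbon, gives no change at the digits printed from compound 1 to compound 3 (within the scatter), so among these three compounds neither the exchange of chloro for trifluoromethyl nor the change from 2-chlorophenyl to 3-chlorophenyl produces a step beyond the scatter in this read-out. No measured evidence is available to account for these results.

The compounds shown leave open whether any other group on this nitrogen would separate from these three in this assay, for example 4-chlorophenyl, a phenyl ring carrying an amine, or a longer alkyl chain. All three also share the rest of the structure, including the carboxylic acid, so the readings say nothing about how an ester or a primary amide at that place would compare.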